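Anilino versus cyclopropylamino on the quinone core

The source may hold more compounds than are shown below. What is called first, only, known or untested is meant among the compounds shown, and "the series" means these compounds.

Three compounds of the series have numbers. Compound 1 `Cc1ccc(NC2=CC(=O)c3nc4n(c3C2=O)[C@H]2OC[C@@H](O)[C@H]2OC4)cc1` in a functional assay on MGC-803 cells (Homo sapiens) for inhibition, read by sulforhodamine B assay (on this read-out lower numbers stand for stronger inhibition and higher numbers for weaker inhibition), gives 1420 nM. Within the data shown here, compound 3 `O=C1C=C(NCc2ccccc2)C(=O)c2c1nc1n2[C@H]2OC[C@@H](O)[C@H]2OC1` in this assay gives 2670 nM; the change a 1.9-fold higher number from compound 1 to compound 3 (0.27 log units; within the scatter) is the only measured step that touches the amine substituent. Compound 2 `O=C1C(NC2CC2)=CC(=O)c2c1nc1n2[C@H]2OC[C@@H](O)[C@H]2OC1` in this assay reaches only a limit of the assay, > 4000 nM, and so stands at the weak end of what is known. Among the measured compounds shown here, the limit of > 4000 nM in this assay, at which 1 of the 3 values shown sits, is the only information on compound 2.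

Compound 4 `Cc1ccc(NC2=CC(=O)c3c(nc4n3[C@H]3OC[C@@H](O)[C@H]3OC4)C2=O)cc1` is not yet measured. It differs from compound 2 by 4-methylphenyl in place of cyclopropyl on an amine nitrogen. For the measured compounds named here, no measured step joins cyclopropylamino to an arylamino group directly; the one available step, a 1.9-fold higher number from compound 1 to compound 3 (0.27 log units; within the scatter), shows that exchanging 4-methylphenyl for benzyl leaves the number within the scatter. Compound 1 with its (4-methylphenyl)amino group gives 1420 nM. Compound 2, by contrast, is known only as a limit of the assay. A lower number for compound 4 than for compound 2 is therefore expected, its size uncertain because compound 2 is known only as the limit > 4000 nM.

The number for compound 4 in this assay is estimated at 1800 nM, within 700 nM to 5000 nM. This estimate implies the step of an at least 2.2-fold lower number from compound 2 to compound 4 (0.34 log units; beyond the scatter).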

Compound 4, half-maximal inhibitory concentration: 1550 nM
Compound 4: the middle estimate sits 1.2-fold (0.06 log units) above what was measured; the measured number falls inside the stated range.
By their numbers in this assay, from the lowest: compounds 1, 4 and 3 (each within the scatter of the next). At a limit, above all of these: compound 2.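

In this assay, among these compounds, the exchange on the amine nitrogen produces a step that lies beyond the scatter, an at least 2.5-fold lower number from compound 2 to compound 4 (0.41 log units; beyond the scatter), which is the first such evidence for this position. Among the compounds shown here, the only earlier step touching the amine substituent, a 1.9-fold higher number from compound 1 to compound 3 (0.27 log units; within the scatter), stayed within the scatter and so could not show that the group on this nitrogen moves the number at all. The new step gives a floor and not a size, because compound 2 is a limit of the assay: the limit of > 4000 nM in this assay, at which 1 of the 4 values shown sits.

The compounds shown leave open whether an open-chain substituent such as ethyl or n-butyl on the same nitrogen would fall with compound 4 or at a limit with compound 2, so the cyclopropyl result cannot yet be read as a result for non-aromatic groups in general. They also leave open what the methyl of the 4-methylphenyl group contributes, which unsubstituted phenyl or 4-methoxyphenyl on this nitrogen would address.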